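A few compounds are considered here, and "the series" means these few. Any claim that something is new, unique, unknown or untested is made for them only; others in the source may bear on it.

Working notes on the series.

For the measured compounds named here, compound 1 `COc1ccc2c(c1)[n+]([O-])c(C#N)c(-c1ccc(C)cc1)[n+]2[O-]` is the first number in an ADME assay on Vero cells (Chlorocebus sabaeus) for cytotoxicity, read by MTT assay, with a stated time of 72 h; a higher number here means a weaker inhibitor, a lower number a stronger inhibitor: compound 1 gives 3.8 ug/mL. Compound 2 `COc1ccc2c(c1)[n+]([O-])c(C#N)c(-c1ccc(OC(F)(F)F)cc1)[n+]2[O-]` carries no result in this assay: for compound 2 the entry reads "not determined" (no result reported). Compound 3 `COC(=O)c1ccc(-c2c(C#N)[n+]([O-])c3cc(Cl)ccc3[n+]2[O-])cc1` gives 20.9 ug/mL in this assay, the highest of the two numbers shown, with the gap to compound 1 beyond the scatter. Compound 4 `COC(=O)c1ccc(-c2c(C#N)[n+]([O-])c3cc(OC)ccc3[n+]2[O-])cc1` is not yet measured; it differs from compound 3 by methoxy in place of chloro on an aromatic carbon. Going by the values given here, no single-point step with this change stands measured in the set, so its size is open. With compound 1 bearing methoxy on the core and giving 3.8 ug/mL, compound 4 is expected to move toward a lower number, by a step of a 1.7-fold lower number from compound 3 to compound 4 (0.24 log units; within the scatter) that may or may not clear the scatter. The estimate for compound 4 in this assay is 12 ug/mL, within 5 ug/mL to 30 ug/mL.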

Compound 4, half-maximal inhibitory concentration: 3.9 ug/mL
Estimate against measurement, compound 4: 3.1-fold (0.49 log units) above; the whole stated range lies above it.
By their numbers in this assay, from the lowest: compounds 1 and 4 (each within the scatter of the next); then compound 3.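

In this assay, for the compounds shown here, methoxy in place of chloro on this aromatic carbon of the shared core gives the first single-place step at this position: a 5.4-fold lower number from compound 3 to compound 4 (0.73 log units; beyond the scatter). With methoxy on the core, methoxycarbonyl in place of methyl on an aromatic carbon gives a 1.0-fold higher number from compound 1 to compound 4 (0.01 log units; within the scatter), so the high number of compound 3 goes with chloro, not with methoxycarbonyl. Nothing at hand gives a reason for either step.

On these data alone, whether an amine or a carboxylic acid at this position would read like methoxy or like chloro stays open. Also open, as far as these compounds go, is whether the step from chloro to methoxy keeps its size with methyl in place of methoxycarbonyl.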